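This account rests on a few compounds, and the source may have more. Where it says the series, first, only, none or still open, it means among the compounds named here.

Three measured compounds share one core and differ only in the groups hung on it. Compound 1 `COc1cccc(CNCc2c(C(=O)O)n(Cc3ccc(O)cc3)c3cc(C(C)C)ccc23)c1` carries a 4-hydroxyphenyl group on the saturated chain carbon bound to the aromatic nitrogen. Compound 2 `COc1cccc(CNCc2c(C(=O)O)n(Cc3ccccc3)c3cc(C)ccc23)c1` and compound 3 `COc1ccc(Cn2c(C(=O)O)c(CNCc3cccc(O)c3)c3ccc(C)cc32)cc1` vary at other places. In a functional assay on SNU-387 cells (Homo sapiens) for antiproliferative activity, read by MTT assay, with a stated time of 72 h (on this read-out higher numbers stand for weaker inhibition and lower numbers for stronger inhibition), compound 1 gives 5130 nM, compound 2 gives 8170 nM and compound 3 gives 9910 nM. Compound 1 has the lowest of the three numbers, but the gaps to compound 2 and to compound 3 both fall within the usual scatter, so no one of the three can be called stronger or weaker than the others.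

The unmeasured compound 4 `COc1cccc(CNCc2c(C(=O)O)n(Cc3ccccc3F)c3cc(C(C)C)ccc23)c1` keeps everything in compound 1 except one group: 2-fluorophenyl in place of 4-hydroxyphenyl on a saturated chain carbon bound to an aromatic nitrogen. Among the measured compounds shown here, no pair of the measured compounds differs in exactly this way, so there is no measured step to lean on. The expectation is therefore modest: in this assay the step of a 1.2-fold higher number from compound 1 to compound 4 (0.07 log units; within the scatter) is expected to stay within the scatter, with no clear direction. Compound 4 is estimated at 6000 nM, most likely between 2500 nM and 15000 nM.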

Compound 4, half-maximal inhibitory concentration: 6090 nM
For compound 4 the middle estimate is 1.0-fold (0.01 log units) below the measured one, and the stated range covers the measured number.
By their numbers in this assay, from the lowest: compounds 1, 4, 2 and 3 (each within the scatter of the next).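

In this assay, putting 2-fluorophenyl in place of 4-hydroxyphenyl on a saturated chain carbon bound to an aromatic nitrogen gives a 1.2-fold higher number from compound 1 to compound 4 (0.07 log units; within the scatter). Among the compounds shown here, this is the first comparison here that changes a single place, and it shows that this exchange leaves the number within the scatter, even though the leaving group has 1 hydrogen-bond donor and 1 hydrogen-bond acceptor and the entering group has 0 of each. No further measurement accompanies this step to account for its size.

For the compounds shown here, this single exchange tests only two aromatic groups at this place, so it cannot show how far the position tolerates change in general. From the compounds shown here alone, a 4-aminophenyl group, a 4-carboxyphenyl group or a longer chain in place of the 4-hydroxybenzyl group remains open, as does whether the same exchange would stay within the scatter on a core carrying methyl rather than the isopropyl group of compound 1.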